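Methyl Beside the Ring Nitrogen of a Biphenyl Amide

A few compounds are considered here, and "the series" means these few. Any claim that something is new, unique, unknown or untested is made for them only; others in the source may bear on it.

Compound 1, `CN1CCCc2ccc(NC(=O)c3ccc(-c4ccccc4)cc3)cc21`, in a functional assay for antagonist activity at transient receptor potential cation channel subfamily V member 1 (Homo sapiens), read by FLIPR and calcium flux (a higher number here means a more potent compound, by a factor of ten per unit of this negative logarithm, a lower number a less potent compound), gives 7.5.
Compound 2, `CN(C)CCN1CCCc2ccc(NC(=O)c3ccc(-c4ccccc4)cc3)cc21`, in this assay gives 7.4.
Compound 3, `O=C(Nc1ccc2cccnc2c1)c1ccc(-c2ccccc2)cc1`, in this assay gives 9.4.

Compound 3 stands highest of the three measured numbers, and its lead over both compound 1 and compound 2 lies beyond the scatter, so it is the most potent compound measured here. Compound 4, `Cc1ccc2ccc(NC(=O)c3ccc(-c4ccccc4)cc3)cc2n1`, differs from compound 3 by methyl in place of hydrogen on an aromatic carbon. Among the compounds with values here, the only measured step, a number 0.10 log units lower from compound 1 to compound 2 (within the scatter), concerns a (dimethylamino)methyl group on a saturated chain carbon and not a methyl on an aromatic ring, so it speaks to this change only loosely; it shows that a small addition at one place left the number unchanged within the scatter. Within the data shown here, no measured pair addresses a methyl on the aromatic ring of the core of compound 3. On that basis, the step from compound 3 to compound 4 is expected to be small, a number 0.20 log units lower from compound 3 to compound 4 (within the scatter), with no direction beyond the scatter firmly indicated. Compound 4 is therefore estimated at 9.2, expected to lie between 8.4 and 9.9.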

Compound 4, negative logarithm of the antagonist equilibrium constant: 8
The estimate for compound 4 lay 1.20 log units above the measured number, and the stated range ends above it.
By their numbers in this assay, from the lowest: compounds 2 and 1 (each within the scatter of the next); then compound 4; then compound 3.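

In this assay, methyl in place of hydrogen on an aromatic carbon next to the ring nitrogen gives a number 1.40 log units lower from compound 3 to compound 4 (beyond the scatter) and so marks this position as sensitive to even a small change. Within the data shown here, the only earlier step was at a different place on a different core and stayed within the scatter, so it gave no sign that a group of just 1 heavy atom could shift the number beyond the scatter. Nothing measured here bears on why the number falls.

The compounds shown leave open whether this drop is specific to methyl or would also follow from fluorine, a methoxy group or an amine on the same aromatic carbon. They also leave open whether methyl on another carbon of this ring would give a comparable drop.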